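The source may report more compounds than this note shows. Statements on the series, on what has been measured and on what is new or still open speak of the compounds shown alone.

Measured so far in a functional assay on the whole organism (strain albino) for inhibition, with Rattus norvegicus as the target, read by paw edema, with stated times of 30 min and 5 h, at a dose of 100 mg/kg by the oral route; a higher number here means more inhibition at the dose given (going by the name of the read-out), a lower number less inhibition: compound 1 `CC(O[N+](=O)[O-])C(=O)Nc1ccc(C(=O)/C=C/c2ccc(Cl)cc2)cc1` gives 56%, compound 2 `COc1ccc(/C=C/C(=O)c2ccc(NC(=O)C(C)O[N+](=O)[O-])cc2)cc1` gives 35%, and compound 3 `C/C(=N/O)c1ccc(OCC(=O)Nc2ccc(C(=O)/C=C/c3ccc(Cl)cc3)cc2)cc1` gives 49%.

From compound 1 to compound 2 the change is methoxy in place of chloro on an aromatic carbon, and in this assay it made a step of a number 21 percentage points lower from compound 1 to compound 2 (beyond the scatter). Compound 4 `COc1ccc(/C=C/C(=O)c2ccc(NC(=O)COc3ccc(/C(C)=N\O)cc3)cc2)cc1` has not yet been measured; it differs from compound 3 by methoxy in place of chloro on an aromatic carbon, the same change at the same kind of place. The difference between the core of compound 1 and the core of compound 3 is not broken down here. The expected step from compound 3 to compound 4 in this assay is a number 19 percentage points lower from compound 3 to compound 4 (beyond the scatter), resting on the earlier step because a number 21 percentage points lower from compound 1 to compound 2 (beyond the scatter) was seen for the same change. Compound 4 is therefore estimated at 30%, with a range from 18% to 42%.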

Compound 4, a percentage reported as inhibition, in the whole organism at one dose (the size of the read-out at that dose, not a potency): 37%
For compound 4 the middle estimate is 7 percentage points below the measured one; the range from low to high includes it.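

In this assay, putting methoxy in place of chloro on the second core gave a number 12 percentage points lower from compound 3 to compound 4 (beyond the scatter), so the change carried over in direction, and the two steps agree in size as far as the scatter allows: the same change on two cores in this assay, a number 21 percentage points lower (beyond the scatter) from compound 1 to compound 2 and a number 12 percentage points lower (beyond the scatter) from compound 3 to compound 4, 9 percentage points apart, within the scatter of two such steps

This rests on just two pairs of compounds, read at one dose and by one read-out. It does not show that the step would hold on a further core, and it does not explain why the methoxy compounds give the lower numbers.

The compounds shown leave open how other groups on that same aromatic carbon would read, such as fluoro, methyl or an amine. They also leave open what a bare phenyl ring would give on either core.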